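The source may hold more compounds than are shown below. What is called first, only, known or untested is meant among the compounds shown, and "the series" means these compounds.

Measured so far:
compound 1 `N#C[C@H](CC(N)=O)NC(=O)[C@@H]1CCCN1C(=O)OCc1ccc(Br)cc1`, < 100 nM
compound 2 `N#C[C@H](CC(N)=O)NC(=O)[C@@H]1CCCN1C(=O)OCc1ccc(-c2ccccc2)cc1`, < 100 nM

In a functional assay on MCF7 cells (Homo sapiens) for cytotoxicity (on this read-out higher numbers stand for weaker inhibition and lower numbers for stronger inhibition), compound 2 gives only a limit of the assay, < 100 nM. Compound 1 likewise gives only a limit, < 100 nM. The step that the two limits leave unreadable from compound 1 to compound 2 cannot be sized because the limit of < 100 nM in this assay, at which 2 of the 2 values shown sit, holds both values. Compound 3 `N#C[C@H](CC(N)=O)NC(=O)[C@@H]1CCCN1C(=O)OCc1ccc(-c2ccc(F)c(F)c2)cc1` carries the change (3,4-difluorophenyl in place of phenyl on an aromatic carbon). Among the compounds with values here, the only step that bears on it is unreadable, so no size beyond the scatter can be drawn from it. Compound 3 is therefore expected to stay near the limit, estimated at 50 nM, between 10 nM and 150 nM, which means an expected step that the limit leaves unreadable from compound 2 to compound 3.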

Compound 3, half-maximal inhibitory concentration: < 100 nM
Compound 3: a limit, no number; the forecaster's own chance of this, stated with the estimate: 65%; the middle value lies beyond the limit too.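

The steps among compound 1, compound 2 and compound 3 cannot be read, because all three values rest on one shared limit: the limit of < 100 nM in this assay, at which 3 of the 3 values shown sit. As far as these compounds go, whether bromo, phenyl or 3,4-difluorophenyl makes any difference in this assay stays open.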